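Benzothiophene amides: cyano in place of chloro

A few compounds are considered here, and "the series" means these few. Any claim that something is new, unique, unknown or untested is made for them only; others in the source may bear on it.

Compound 3 `O=C(NC1CCN(Cc2ccc(OC3CCNCC3)c(Br)c2)CC1)c1cc2cc(Cl)ccc2s1` gives 51 nM in an assay on HEK293 cells for displacement of a labelled ligand from Urotensin-2 receptor (Homo sapiens), read by fluorescence, with a stated time of 90 min (a higher number here means a weaker inhibitor, a lower number a stronger inhibitor), the lowest number among the three measured compounds, though compound 2 `O=C(NC1CCN(Cc2ccc(OC3CCNCC3)c(Br)c2)CC1)c1cc2ccccc2s1`, at 63 nM, lies within the scatter of it; compound 1 `O=C(NC1CCN(Cc2ccc(OC3CCNCC3)c(Br)c2)CC1)c1cscn1` gives the highest number at 970 nM. The next compound, compound 4 `N#Cc1ccc2cc(C(=O)NC3CCN(Cc4ccc(OC5CCNCC5)c(Br)c4)CC3)sc2c1`, carries the change (6-cyano-1-benzothiophen-2-yl in place of 5-chloro-1-benzothiophen-2-yl on a carbonyl carbon). Two kinds of measured step bear on it. The large drops a 15-fold lower number from compound 1 to compound 2 (1.19 log units; beyond the scatter) and a 19-fold lower number from compound 1 to compound 3 (1.28 log units; beyond the scatter) came with the 1-benzothiophen-2-yl group replacing 1,3-thiazol-4-yl, and that group is retained in compound 4. Among the compounds with values here, the only step that alters a substituent on that group, a 1.2-fold lower number from compound 2 to compound 3 (0.09 log units; within the scatter), stayed within the scatter, so a change of substituent there has so far not moved this assay . Nothing is shown for a cyano group, and the expectation rests on that single step alone. The estimate for compound 4 is therefore a step of a 1.2-fold higher number from compound 3 to compound 4 (0.07 log units; within the scatter), not beyond the scatter. Compound 4 is expected at 60 nM, within 20 nM to 200 nM.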

Compound 4, half-maximal inhibitory concentration: 80 nM
The estimate for compound 4 lay 1.3-fold (0.12 log units) below the measured number; the range from low to high includes it.
By their numbers in this assay, from the lowest: compounds 3, 2 and 4 (each within the scatter of the next); then compound 1.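

In this assay, the nitrile gives a 1.3-fold higher number from compound 2 to compound 4 (0.10 log units; within the scatter) and, set against the chloro group, a 1.6-fold higher number from compound 3 to compound 4 (0.20 log units; within the scatter), so a second, different substituent on the 1-benzothiophen-2-yl group also stays within the scatter, this time at another ring position. The large step away from 1,3-thiazol-4-yl also holds for the cyano compound, with a 12-fold lower number from compound 1 to compound 4 (1.08 log units; beyond the scatter), and now stands for the unsubstituted, chloro and cyano groups of compounds 2, 3 and 4. No measurement shown explains why these substituents leave the number within the scatter.

The step from compound 3 to compound 4 changes both the substituent and its ring position, so the two effects cannot be separated. Going by these compounds, whether a charged or larger substituent, such as a carboxylic acid, an aminomethyl group or a longer alkyl chain, would also stay within the scatter remains open.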